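A few compounds are considered here, and "the series" means these few. Any claim that something is new, unique, unknown or untested is made for them only; others in the source may bear on it.

In an assay on cells for inhibition of protein deacetylase HDAC6 (Homo sapiens), read by fluorescence, with stated times of 15 min and 60 min (a higher number here means a weaker inhibitor, a lower number a stronger inhibitor), compound 1 `Cc1cc(-c2ccc(F)cc2)nn1Cc1ccc(C(=O)NO)cc1` gives 8 nM. Compound 2 `O=C(CCNC(=O)c1cc(-c2ccc(F)cc2)[nH]n1)NO` returns only a limit of the assay here, > 5000 nM, as noted in the limit of > 5000 nM in this assay, at which 1 of the 2 values shown sits. Of the two values shown, compound 2 stands at that limit, with no number beneath it. Compound 3 `O=C(CCCNC(=O)c1cc(-c2ccc(F)cc2)[nH]n1)NO` is not yet measured; it differs from compound 2 by (hydroxycarbamoyl)methyl in place of hydroxycarbamoyl on a saturated chain carbon, two bonds along the chain from an amide-type nitrogen. Going by the values given here, no measured pair shows this change, so its size is unknown; only a small movement in this assay is expected, with no clear direction beyond the scatter, and an estimated step that the limit leaves unreadable from compound 2 to compound 3 is expected. Compound 3 is estimated at 6000 nM, within 1500 nM to 20000 nM, most likely again as a limit only.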

Compound 3, half-maximal inhibitory concentration: 1060 nM
The estimate for compound 3 lay 5.7-fold (0.75 log units) above the measured number; the measured number lies below the stated range.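

In this assay, (hydroxycarbamoyl)methyl in place of hydroxycarbamoyl on this saturated chain carbon gives an at least 4.7-fold lower number from compound 2 to compound 3 (0.67 log units; beyond the scatter). This position therefore responds to the change, and the lengthened chain moves the series from a limit to a readable number. The size of the step remains open-ended, as compound 2 gives only a limit: the limit of > 5000 nM in this assay, at which 1 of the 3 values shown sits.

From the compounds shown here alone, whether a longer chain lowers the number further remains open, as does whether a carboxylic acid can replace the hydroxycarbamoyl end. Compound 1 differs from this pair in more than one place, so it does not show how chain length acts.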